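Working notes: aryloxy exchange from compound 2 to compound 3

This account rests on a few compounds, and the source may have more. Where it says the series, first, only, none or still open, it means among the compounds named here.

Measured so far:
compound 1, `CCc1cc(C)c(C(=O)N=C(N)N)cc1S(C)(=O)=O`, gives 4.8 nM in a functional assay for inhibition of sodium/hydrogen exchanger (Oryctolagus cuniculus); a lower number here means a stronger inhibitor, a higher number a weaker inhibitor.
compound 2, `Cc1cc(Oc2ccccc2)c(S(C)(=O)=O)cc1C(=O)N=C(N)N`, gives 10 nM in this assay.

Compound 2 stands at the highest of the two numbers; its nearest neighbour is compound 1, the step being a 2.1-fold higher number from compound 1 to compound 2 (0.32 log units; beyond the scatter). That single step, phenoxy in place of ethyl on an aromatic carbon, is modest but beyond the scatter.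

Compound 3, `Cc1cc(Oc2cccnc2)c(S(C)(=O)=O)cc1C(=O)N=C(N)N`, has not yet been measured in this assay. It differs from compound 2 by pyridin-3-yl in place of phenyl on an oxygen on an aromatic ring. Among the compounds with values here, no measured step touches this exchange: the one step available, a 2.1-fold higher number from compound 1 to compound 2 (0.32 log units; beyond the scatter), concerns the group on the aromatic carbon rather than the group on the oxygen, so it offers only a loose anchor. Within the data shown here, with the aryl ring retained and only one ring atom exchanged, no step beyond the scatter is expected. Compound 3 is therefore estimated at 12 nM, with a range from 5 nM to 30 nM. The expected step from compound 2 to compound 3 is a 1.2-fold higher number from compound 2 to compound 3 (0.08 log units; within the scatter), in effect none beyond the scatter.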

Compound 3, half-maximal inhibitory concentration: 8.8 nM
Compound 3: middle estimate off by 1.4-fold (0.13 log units), on the high side, and the stated range covers the measured number.
By their numbers in this assay, from the lowest: compounds 1, 3 and 2 (each within the scatter of the next, the first and the last beyond it).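

In this assay the group on the oxygen accepts a ring-atom exchange: pyridin-3-yl in place of phenyl gives a 1.1-fold lower number from compound 2 to compound 3 (0.06 log units; within the scatter) and so adds a ring nitrogen and a hydrogen-bond acceptor with no shift beyond the scatter. Measured against the ethyl of compound 1, the new group gives a 1.8-fold higher number from compound 1 to compound 3 (0.26 log units; within the scatter) while phenoxy gave a 2.1-fold higher number from compound 1 to compound 2 (0.32 log units; beyond the scatter), yet this contrast is slight, since compound 2 and compound 3 lie within the scatter of each other and the aryloxy groups cannot be told apart here. No measurement at hand accounts for the flat response to this exchange.

Still open, going by these compounds, is how the number responds to pyridin-4-yl on the same oxygen, or to an amine or a carboxylic acid carried on the ring of the aryloxy group. Also open, on these data alone, is whether an aromatic ring is needed on this oxygen at all, a question that a cyclohexyl group or a plain methyl in its place would address.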